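The compounds below may be only part of what the source reports. "The series", "measured", "known", "first", "only" and "open" are said of these compounds alone.

Compound 3 `CN(C)C(=O)c1cccnc1NCCCN1CCN(c2ccccc2OC(F)(F)F)CC1` gives 3.16 nM in a functional assay for antagonist activity at Alpha-1A adrenergic receptor (Oryctolagus cuniculus) (on this read-out higher numbers stand for weaker binding and lower numbers for tighter binding), the highest of the three numbers recorded here. Compound 1 `COc1ccccc1N1CCN(CCCNc2ncccc2C(=O)NC(C)(C)C)CC1` gives 1.26 nM, and compound 2 `CCOc1ccccc1N1CCN(CCCNc2ncccc2C(=O)N(C)C)CC1` gives 0.501 nM. Among the compounds with values here, the only measured step at this position, a 6.3-fold higher number from compound 2 to compound 3 (0.80 log units; beyond the scatter), came with trifluoromethyl in place of ethyl on an oxygen on an aromatic ring. Compound 4 `CN(C)C(=O)c1cccnc1NCCCN1CCN(c2ccccc2-c2ccccc2)CC1` differs from compound 3 by phenyl in place of trifluoromethoxy on an aromatic carbon. Within the data shown here, no measured step replaces this oxygen-bearing group with a ring, so the one known step bears on it only loosely; as the number rose when the group on that oxygen was changed, a further modest rise is expected, a 3.2-fold higher number from compound 3 to compound 4 (0.50 log units; beyond the scatter). Compound 4 is therefore estimated at 10 nM, within a range from 2 nM to 50 nM.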

Compound 4, dissociation constant: 1.26 nM
Beside the measured number, compound 4's estimate is 7.9-fold (0.90 log units) above it; measured number outside the range, below it.
By their numbers in this assay, from the lowest: compound 2; then compounds 1 and 4 (each within the scatter of the next); then compound 3.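

In this assay, the step from trifluoromethoxy to phenyl, a 2.5-fold lower number from compound 3 to compound 4 (0.40 log units; beyond the scatter), shows that this place accepts an aromatic ring of carbon only, with no oxygen on the aromatic carbon. Phenyl still does not match ethoxy, given a 2.5-fold higher number from compound 2 to compound 4 (0.40 log units; beyond the scatter), so ethoxy keeps the lowest number of these three groups on the dimethyl amide. No evidence here accounts for either step. Open, on these data alone, is how a saturated cyclohexyl ring, a pyridine ring or a methoxy-substituted phenyl would fare at this place. Also open, as far as these compounds go, is whether phenyl behaves the same with the tert-butyl amide of compound 1.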